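From Fluoro to Methyl in an Antiproliferative Series

This account rests on a few compounds, and the source may have more. Where it says the series, first, only, none or still open, it means among the compounds named here.

Compound 1 `COc1cc(C(=O)c2sc(-c3ccc(Cl)cc3)cc2N)cc(OC)c1OC` gives 93 nM
Compound 2 `COc1cc(C(=O)c2sc(-c3cccc([N+](=O)[O-])c3)cc2N)cc(OC)c1OC` gives 11 nM
Compound 3 `COc1cc(C(=O)c2sc(-c3ccc(F)cc3)cc2N)cc(OC)c1OC` gives 20 nM
Compound 4 `COc1cc(C(=O)c2sc(-c3ccc(C)cc3)cc2N)cc(OC)c1OC` has no measurement yet

In a functional assay on L1210 cells (Mus musculus) for antiproliferative activity (on this read-out higher numbers stand for weaker inhibition and lower numbers for stronger inhibition), compound 3 (20 nM) cannot be separated from compound 2, since the step is a 1.8-fold higher number from compound 2 to compound 3 (0.26 log units; within the scatter). Compound 3 stands clearly lower than compound 1, with the step being a 4.7-fold lower number from compound 1 to compound 3 (0.67 log units; beyond the scatter). Compound 2 also differs clearly from compound 1, with an 8.5-fold lower number from compound 1 to compound 2 (0.93 log units; beyond the scatter).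

The next change puts methyl in place of fluoro on an aromatic carbon, para to a large group, taking 4-fluorophenyl to 4-methylphenyl (methyl in place of fluoro on an aromatic carbon). Among the compounds with values here, compound 1 offers the closest guide, as its step to compound 3 is the only measured swap of one group at this same place, and that step is a 4.7-fold lower number from compound 1 to compound 3 (0.67 log units; beyond the scatter). The step involving compound 2 also alters where the group sits, so it bears less directly. Within the data shown here, no measured pair contains methyl, which leaves the direction uncertain. A modest rise at most is expected in this assay, probably not beyond the scatter. The expected step is a 1.8-fold higher number from compound 3 to compound 4 (0.24 log units; within the scatter). For compound 4 the estimated value is 35 nM, with an expected range from 12 nM to 110 nM.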

Compound 4, half-maximal inhibitory concentration: 18 nM
Compound 4: the middle estimate sits 1.9-fold (0.29 log units) above what was measured; measured number inside the range.
By their numbers in this assay, from the lowest: compounds 2, 4 and 3 (each within the scatter of the next); then compound 1.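

In this assay, methyl in place of fluoro on an aromatic carbon, para to a large group, gives a step that cannot be told from the scatter (a 1.1-fold lower number from compound 3 to compound 4 (0.05 log units; within the scatter)), so the earlier result with fluoro at this place now has a methyl counterpart that reads the same. Within the data shown here, the step from the 3-nitrophenyl compound is also within the scatter (a 1.6-fold higher number from compound 2 to compound 4 (0.21 log units; within the scatter)), whereas the step from the 4-chlorophenyl compound lies beyond it (a 5.2-fold lower number from compound 1 to compound 4 (0.71 log units; beyond the scatter)), so chloro is the only one of the three groups at this place that stands apart, and the new result gives that separation a second, independent comparison alongside the one with fluoro. Nothing presented here explains why methyl and fluoro read alike at this place or why chloro differs from both.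

The compounds shown leave open how an amine, a carboxylic acid or a longer chain such as propyl would read at this same place on the phenyl ring. They also leave open whether the gap between chloro and the other two groups would persist on any read-out other than this one, since all four compounds are compared in a single cell assay.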